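Swapping the aryl group on the sulfonyl sulfur at a limit

The source may hold more compounds than are shown below. What is called first, only, known or untested is meant among the compounds shown, and "the series" means these compounds.

Measured so far in an ADME assay on HCT-116 cells (Homo sapiens) for cytotoxicity, read by CellTiter-Glo, with a stated time of 72 h; on this read-out lower numbers stand for stronger inhibition and higher numbers for weaker inhibition
Compound 1 `Cc1ccc(S(=O)(=O)N2CCC(N3CCC(C)CC3)CC2)cc1C` gives > 5000 nM as a limit
Compound 2 `CC1CCN(C2CCN(S(=O)(=O)c3ccc(Cl)nc3)CC2)CC1` gives > 10000 nM as a limit
Compound 3 `CC1CCN(C2CCN(S(=O)(=O)c3ccc(Br)c(Cl)c3)CC2)CC1` gives > 5000 nM as a limit

None of these entries is an exact number, and two limits occur among them: the limit of > 10000 nM in this assay, at which 1 of the 3 values shown sits, and the limit of > 5000 nM in this assay, at which 2 of the 3 values shown sit, in all. Compound 3 therefore has no exact place on the scale, only its limit of > 5000 nM in this assay for now.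

Compound 4 `CC1CCN(C2CCN(S(=O)(=O)c3cncc(Br)c3)CC2)CC1` has not yet been measured. It differs from compound 3 in one place, and the counted change is 5-bromopyridin-3-yl in place of 4-bromo-3-chlorophenyl on a sulfonyl sulfur on the sulfonyl sulfur. In plain words, 5-bromopyridin-3-yl takes the place of 4-bromo-3-chlorophenyl there.

Three measured changes at this same place bear on it: a step that the two limits leave unreadable from compound 1 to compound 2 and a step that the two limits leave unreadable from compound 1 to compound 3 and also a step that the two limits leave unreadable from compound 2 to compound 3 here. None of these steps has a readable size, so none gives a direction. Compound 2 also carries a pyridine-based group, 6-chloropyridin-3-yl, and it reads > 10000 nM as a limit too.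

No step beyond the scatter is therefore expected in this assay and no direction can be named. The expected size is a step that the limit leaves unreadable from compound 3 to compound 4 in this comparison, and another limit is the likeliest report. For compound 4 the estimate is 10000 nM with an expected range of 5000 nM to 20000 nM overall.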

Compound 4, half-maximal inhibitory concentration: > 10000 nM
Compound 4 gave a limit, no number; the forecaster's own chance of this, stated with the estimate: 90%; the middle value sits exactly at the limit.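

In this assay compound 4 gives > 10000 nM, which is a limit and not a number. Going by these compounds alone, no step to compound 4 from compound 1, compound 2 or compound 3 can therefore be read. The compounds shown leave open what exact value any of them would give, and whether changing the aryl group on the sulfonyl sulfur shifts that value at all.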